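The source may hold more compounds than are shown below. What is called first, only, known or untested is meant among the compounds shown, and "the series" means these compounds.

In a functional assay on HepG2 cells (Homo sapiens) for inhibition, read by sulforhodamine B assay, with a stated time of 72 h (on this read-out lower numbers stand for stronger inhibition and higher numbers for weaker inhibition), compound 1 (`C[C@H](Nc1nc(N)nc2[nH]cnc12)c1nn(-c2cccnc2)c2cc(F)ccc12`) is reported only as a limit, > 40000 nM, and not as a number. the limit of > 40000 nM in this assay, at which 1 of the 3 values shown sits, is the only such limit in this small set. Compound 2 (`C[C@H](Nc1ncnc2[nH]cnc12)c1nn(-c2cccnc2)c2cc(F)ccc12`) gives 37500 nM, and compound 3 (`CC[C@H](Nc1ncnc2[nH]cnc12)c1nn(-c2cccnc2)c2cc(F)ccc12`) gives 33900 nM. These two numbers lie within the scatter of each other, so compound 2 stands level with compound 3 on the evidence available.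

Two measured steps start from or end at compound 2. Hydrogen in place of amino gives an at least 1.0-fold lower number from compound 1 to compound 2 (0.02 log units; that floor lies within the scatter), which is only a floor. Methyl in place of hydrogen on the chain gives a 1.1-fold lower number from compound 2 to compound 3 (0.04 log units; within the scatter). Compound 4 (`C[C@H](Nc1ncnc2[nH]cnc12)c1nn(-c2ccncc2)c2cc(F)ccc12`) makes a different change: pyridin-4-yl in place of pyridin-3-yl on an aromatic nitrogen, with pyridin-4-yl in place of pyridin-3-yl on an aromatic nitrogen. The same atoms are present, joined differently.

Neither measured step touches this group, so neither bears on the change directly, and the data hold no earlier swap of this kind. Going by the values given here, they show only that the compounds so far sit close together, with compound 2 at 37500 nM, and no step beyond the scatter is expected in this assay. The expected result is a 1.3-fold lower number from compound 2 to compound 4 (0.10 log units; within the scatter). Compound 4 is estimated at 30000 nM, with an expected range from 11000 nM to 50000 nM.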

Compound 4, half-maximal inhibitory concentration: 23100 nM
The estimate for compound 4 lay 1.3-fold (0.11 log units) above the measured number, and the stated range covers the measured number.
By their numbers in this assay, from the lowest: compounds 4, 3 and 2 (each within the scatter of the next). At a limit, above all of these: compound 1.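

The swap of pyridin-3-yl for pyridin-4-yl, on an aromatic nitrogen of the five-membered aromatic ring, gives a 1.6-fold lower number from compound 2 to compound 4 (0.21 log units; within the scatter) in this assay. Going by these compounds alone, this is the first measured step at this position, since the earlier steps touched only the amino group on an aromatic carbon and the saturated chain, and it shows that joining the same atoms differently within this group leaves the two compounds level on the evidence available. Nothing measured here gives a reason for the size of this step, and no property of either group bears on it.

What the compounds shown leave open is whether this position can give a step beyond the scatter at all, since the only comparison so far is between two pyridine isomers with the same counts of atoms, donors and acceptors. A pyridin-2-yl group, a plain phenyl ring, a phenyl ring carrying an amine or a carboxylic acid, or a small alkyl chain in this place could each answer that, and the same holds for pyridin-4-yl combined with the longer chain of compound 3.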